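The compounds below may be only part of what the source reports. "The series", "measured", "known", "first", "only" and "open" are said of these compounds alone.

Compound 1 `COc1cccc(CNCCCNS(=O)(=O)c2cc(C(F)(F)F)cc(C(F)(F)F)c2)c1` gives 10000 nM in a functional assay on HT-29 cells (Homo sapiens) for inhibition, read by MTT assay, with a stated time of 72 h; a higher number here means a weaker inhibitor of growth, a lower number a stronger inhibitor of growth. Compound 2 `CN(CCCNS(=O)(=O)c1cc(C(F)(F)F)cc(C(F)(F)F)c1)Cc1ccccc1` gives > 50000 nM in this assay, which is a limit of the assay and not a number. Compound 3 `COc1ccccc1CNCCCNS(=O)(=O)c1cc(C(F)(F)F)cc(C(F)(F)F)c1` gives 12000 nM in this assay.

Compound 3 and compound 1 sit together, since the step of a 1.2-fold higher number from compound 1 to compound 3 (0.08 log units; within the scatter) lies within the scatter. The step of an at least 5.0-fold higher number from compound 1 to compound 2 (0.69 log units; beyond the scatter) and the step of an at least 4.1-fold lower number from compound 2 to compound 3 (0.61 log units; beyond the scatter) concern a different change and do not bear on what follows.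

Compound 4 `COc1ccc(CNCCCNS(=O)(=O)c2cc(C(F)(F)F)cc(C(F)(F)F)c2)cc1` differs from compound 3 by 4-methoxyphenyl in place of 2-methoxyphenyl on a saturated chain carbon bound to an amine nitrogen. Among the compounds with values here, the only measured step that moves the methoxy group around the ring, from compound 1 to compound 3, stayed within the scatter, so no step beyond the scatter is expected in this assay: the expected step is no change at the digits printed from compound 3 to compound 4 (within the scatter). Compound 4 is estimated at 12000 nM, within a range from 5000 nM to 30000 nM.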

Compound 4, concentration for 50% growth inhibition: 2900 nM
Beside the measured number, compound 4's estimate is 4.1-fold (0.62 log units) above it, outside the stated range (below it).
By their numbers in this assay, from the lowest: compound 4; then compounds 1 and 3 (each within the scatter of the next). At a limit, above all of these: compound 2.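

The position of the methoxy group on the ring does matter: with 4-methoxyphenyl in place of 2-methoxyphenyl there is a 4.1-fold lower number from compound 3 to compound 4 (0.62 log units; beyond the scatter), and with 4-methoxyphenyl in place of 3-methoxyphenyl there is a 3.4-fold lower number from compound 1 to compound 4 (0.54 log units; beyond the scatter), while the earlier swap between the 2-methoxyphenyl and 3-methoxyphenyl groups stayed within the scatter. With (4-methoxybenzyl)amino in place of benzyl(methyl)amino there is an at least 17-fold lower number from compound 2 to compound 4 (1.23 log units; beyond the scatter). That step starts from compound 2, whose value is a limit of the assay and not a number: the limit of > 50000 nM in this assay, at which 1 of the 4 values shown sits.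

As far as these compounds go, it remains open whether the methoxy group itself is needed, or whether 4-chlorophenyl or 4-hydroxyphenyl would serve as well in this place.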